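A chloro swap on the higher of two compounds

The source may report more compounds than this note shows. Statements on the series, on what has been measured and on what is new or still open speak of the compounds shown alone.

Among the measured compounds shown here, only two compounds built on a shared core have been measured so far. In a functional assay on A549 cells (Homo sapiens) for inhibition, read by sulforhodamine B assay, with a stated time of 48 h, tested at 10 uM (a higher number here means more inhibition of growth at the concentration tested, a lower number less inhibition of growth), compound 1 `COc1ccc(-c2nc3sc(-c4ccccc4)cn3n2)cc1` gives 49%, and compound 2 `COc1cc(-c2nc3sc(-c4ccccc4)cn3n2)cc(OC)c1OC` gives 23%. That puts compound 1 at the top of the two numbers, with a gap beyond the usual scatter.

The next compound, compound 3 `COc1ccc(-c2nc3sc(-c4ccc(Cl)cc4)cn3n2)cc1`, keeps the core of compound 1 and alters one spot: chloro in place of hydrogen on an aromatic carbon. This is chloro in place of hydrogen on an aromatic carbon, turning phenyl to 4-chlorophenyl. Neither measured compound carries this change, so the data offer no direct guide to its effect. With that gap in mind, no shift beyond the scatter is expected in this assay. The estimated step is a number 1 percentage points higher from compound 1 to compound 3 (within the scatter), in either direction a small one. For compound 3 the estimated value is 50%, with an expected range from 30% to 70%.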

Compound 3, percent growth inhibition at one concentration: -30%
Compound 3: middle estimate off by 80 percentage points, on the high side; measured number outside the range, below it.
By their numbers in this assay, from the lowest: compound 3; then compound 2; then compound 1.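

In this assay the change from phenyl to 4-chlorophenyl gives a number 79 percentage points lower from compound 1 to compound 3 (beyond the scatter) and so shows that this spot on the ring, para to a large group, strongly affects the reading. Compound 1 and compound 2 both carry the plain phenyl, so they could say nothing about this position, whereas compound 3 at -30% shows that one chloro in place of hydrogen can take the reading below zero. No measurement at hand explains why this single swap has so large an effect.

As far as these compounds go, it remains open whether this drop belongs to chloro itself or would follow any group placed here, which a fluoro, a methoxy or an amine at the same spot could help to separate. From the compounds shown here alone, it is also open whether the same swap would move compound 2 in the same way.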